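Methyl in place of chloro on the aryl of compound 2

The source may report more compounds than this note shows. Statements on the series, on what has been measured and on what is new or still open speak of the compounds shown alone.

Measured compounds:
compound 1, `Cc1ccc(C2CN(C)Cc3c(N)cccc32)cc1`: in a functional assay on the whole organism for inhibition of sodium-dependent dopamine transporter (Mus musculus) (on this read-out lower numbers stand for an effect already at smaller amounts and higher numbers for an effect only at larger amounts of compound), compound 1 gives about 22 mg/kg
compound 2, `CCCCNC(=O)Nc1cccc2c1CN(C)CC2c1ccc(Cl)cc1`: in this assay compound 2 gives about 120 mg/kg

Compound 2 stands at the higher of the two numbers recorded in this assay; the gap to compound 1 lies beyond the usual scatter. Compounds 1 and 2 differ in two places at once, on the aryl group and on the shared core, so the two values alone do not tell which of the two differences carries the gap.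

Compound 3, `CCCCNC(=O)Nc1cccc2c1CN(C)CC2c1ccc(C)cc1`, is the unmeasured member. It is compound 2 with methyl in place of chloro on an aromatic carbon; the butylurea on the core is kept. Going by the values given here, compound 1 carries the same methyl-bearing aryl but a different group on the core, so no measured pair isolates this change. With nothing to anchor it, the step from compound 2 to compound 3 in this assay is expected to be small, at most a modest move toward lower numbers and quite possibly none beyond the scatter. The estimate for compound 3 is 90 mg/kg, with a range of 35 mg/kg to 250 mg/kg, which means an expected step of a 1.3-fold lower number from compound 2 to compound 3 (0.12 log units; within the scatter).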

Compound 3, dose for half-maximal effect: > 100 mg/kg
Compound 3 gave a limit, no number; the forecaster's own chance of this, stated with the estimate: 20%; middle value at least 1.1-fold (0.04 log units) from the limit.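

In this assay compound 3 gives > 100 mg/kg, which is a limit of the assay and not a number. With the 4-methylphenyl group held fixed, the earlier pair could not isolate the core difference, whereas butylcarbamoyl in place of hydrogen on a nitrogen on an aromatic ring now gives an at least 4.5-fold higher number from compound 1 to compound 3 (0.65 log units; beyond the scatter), so the butylurea on the shared core goes with a move toward higher numbers in this series. The step for methyl in place of chloro on the aromatic carbon cannot be read, and compound 2 and compound 3 can be given no order, because one of the two is held only as a limit: the limit of > 100 mg/kg in this assay, at which 1 of the 3 values shown sits.

Still open, on these data alone, is how the 4-chlorophenyl group behaves on the core of compound 1, with the plain amine kept, which is the pairing that could give the aryl change a readable step in this assay. Also open, as far as these compounds go, is whether the move belongs to the urea as such or to its butyl chain, a question that a methyl urea, a longer chain on the urea or a simple acetamide in its place would bear on.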